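This account rests on a few compounds, and the source may have more. Where it says the series, first, only, none or still open, it means among the compounds named here.

Compound 3 `COc1ccc(C2CC(c3ccccc3)=NN2c2ccc(-c3ccccc3)nn2)c(OC)c1` has been tested in a functional assay on Caco-2 cells (Homo sapiens) for antiproliferative activity, read by MTT assay, with a stated time of 24 h (a higher number here means a weaker inhibitor, a lower number a stronger inhibitor), where compound 3 gives only a limit of the assay, > 100000 nM. Compound 2 `COc1ccc(C2CC(c3ccccc3)=NN2c2ccc(-c3ccccc3)nn2)cc1` likewise returns only a limit in this assay, > 100000 nM. Compound 1 `FC(F)(F)c1ccc(C2CC(c3ccccc3)=NN2c2ccc(-c3ccccc3)nn2)cc1` gives 50000 nM in this assay, and the step of an at least 2.0-fold higher number from compound 1 to compound 3 (0.30 log units; that floor lies within the scatter) places compound 3 at the weaker end of what is seen. Compound 4 `COc1ccc(C2=NN(c3ccc(-c4ccccc4)nn3)C(c3ccc(OC)cc3OC)C2)cc1` differs from compound 3 by methoxy in place of hydrogen on an aromatic carbon. For the measured compounds named here, the only measured step of the same kind, a step that the two limits leave unreadable from compound 2 to compound 3, has no readable size, and the limit of > 100000 nM in this assay, at which 2 of the 3 values shown sit, marks where most values sit. No step beyond the scatter is therefore expected, and the expected step that the limit leaves unreadable from compound 3 to compound 4 is small. Compound 4 is estimated at 150000 nM, between 60000 nM and 400000 nM, most probably again reported only as a limit.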

Compound 4, half-maximal inhibitory concentration: > 100000 nM
Compound 4 was reported as a limit (the forecaster's own chance of this, stated with the estimate: 80%); the middle value is on the limit's open side.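

For the compounds shown here, compound 3 and compound 4 both return only a limit in this assay, so no step between them can be read. Whether the added methoxy changes the activity at all stays open, and one point holds most of the results: the limit of > 100000 nM in this assay, at which 3 of the 4 values shown sit.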